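The source may hold more compounds than are shown below. What is called first, only, known or untested is meant among the compounds shown, and "the series" means these compounds.

Values in a functional assay on U-373MG ATCC cells (Homo sapiens) for cytotoxicity, read by MTT assay (on this read-out lower numbers stand for stronger inhibition and higher numbers for weaker inhibition), for the measured compounds:
compound 1 `Oc1ccc(CN(Cc2ccccc2C(F)(F)F)Cc2ccc(O)c3ncccc23)c2cccnc12` gives 78 nM
compound 2 `Oc1ccc(CN(Cc2cccc(C(F)(F)F)c2)Cc2ccc(O)c3ncccc23)c2cccnc12` gives 65 nM
compound 3 `Oc1ccc(CN(Cc2cc(C(F)(F)F)cc(C(F)(F)F)c2)Cc2ccc(O)c3ncccc23)c2cccnc12` gives 96 nM

Compound 2 gives 65 nM and is not separated from the other two compounds: its two steps, a 1.2-fold lower number from compound 1 to compound 2 (0.08 log units; within the scatter) and a 1.5-fold higher number from compound 2 to compound 3 (0.17 log units; within the scatter), both stay within the scatter.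

For the measured compounds named here, compound 4 `O=C(O)C1CCC(CN(Cc2ccc(O)c3ncccc23)Cc2ccc(O)c3ncccc23)CC1` is still to be measured, and its change from compound 2 is of another kind: 4-carboxycyclohexyl in place of 3-(trifluoromethyl)phenyl on a saturated chain carbon bound to an amine nitrogen is an exchange that no measured step covers. Neither a 1.2-fold lower number from compound 1 to compound 2 (0.08 log units; within the scatter) nor a 1.5-fold higher number from compound 2 to compound 3 (0.17 log units; within the scatter) removes the phenyl ring or brings in a carboxy group. Going by the values given here, both therefore bear on this change only weakly, and they show only that the number holds still while a phenyl ring carrying trifluoromethyl stays in place. The series offers no direct reading for the loss of that ring.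

A rise in the number beyond the scatter is expected, but this is a judgement rather than a trend in the data. In this assay the expected step is a 3.8-fold higher number from compound 2 to compound 4 (0.59 log units; beyond the scatter) and it carries wide uncertainty. The estimated value for compound 4 is 250 nM with 70 nM to 1200 nM as the expected range.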

Compound 4, half-maximal inhibitory concentration: 3730 nM
Beside the measured number, compound 4's estimate is 15-fold (1.17 log units) below it; the whole stated range lies below it.
By their numbers in this assay, from the lowest: compounds 2, 1 and 3 (each within the scatter of the next); then compound 4.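

In this assay, the substituent on the saturated chain carbon bound to an amine nitrogen turns out to matter a great deal, with a 57-fold higher number from compound 2 to compound 4 (1.76 log units; beyond the scatter) and a 48-fold higher number from compound 1 to compound 4 (1.68 log units; beyond the scatter) when 4-carboxycyclohexyl takes the place of the phenyl rings carrying trifluoromethyl. The earlier compounds shown here showed a flat response only while such a ring stayed in place; the series now shows that this flatness does not extend to a non-aromatic ring carrying a carboxy group, and that the number can move far beyond the scatter from this one position. Nothing available accounts for the size of this rise.

The exchange removes the aromatic ring and the trifluoromethyl group and brings in the non-aromatic ring and the carboxy group all at once, so the compounds shown leave open which of these changes carries the step. A plain cyclohexyl group, a phenyl ring bearing a carboxylic acid, or a cyclohexyl group bearing a methyl ester at this place would separate these contributions.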